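From 4-bromophenyl to 2,4-dichlorophenyl in a growth assay

The source may report more compounds than this note shows. Statements on the series, on what has been measured and on what is new or still open speak of the compounds shown alone.

Compounds measured in a functional assay on ACHN cells (Homo sapiens); a lower number here means a stronger inhibitor of growth, a higher number a weaker inhibitor of growth:
Compound 1 `N#Cc1ccc(/C=C/S(=O)(=O)Cc2ccc(Nc3ncnc4ccccc34)cc2)cc1`: > 100000 nM (a limit)
Compound 2 `O=S(=O)(/C=C/c1ccc(Br)cc1)Cc1ccc(Nc2ncnc3ccccc23)cc1`: 200 nM

For the measured compounds named here, compound 2, at 200 nM, holds the only actual number in this small set. Compound 1 gives only a limit of the assay, > 100000 nM.

Compound 3 `O=S(=O)(/C=C/c1ccc(Cl)cc1Cl)Cc1ccc(Nc2ncnc3ccccc23)cc1` is next in line. It carries 2,4-dichlorophenyl in place of 4-bromophenyl on a double-bonded chain carbon bound to a double-bonded chain carbon.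

Going by the values given here, only one measured step bears on this change: an at least 500-fold lower number from compound 1 to compound 2 (2.69 log units; beyond the scatter), with bromo in place of cyano on an aromatic carbon. That large step shows that a single change on this aromatic ring can move the number far in this assay. However, it concerns a nitrile, which neither compound 2 nor compound 3 carries, so it gives no direction here. Compound 3 keeps halogen on the ring, so no step beyond the scatter is expected. Among the compounds with values here, the expected step is a 1.3-fold higher number from compound 2 to compound 3 (0.10 log units; within the scatter), and the wide range reflects how sharply the one measured step moved. For compound 3 the estimate is 250 nM, with an expected range from 60 nM to 1500 nM.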

Compound 3, concentration for 50% growth inhibition: 100 nM
The estimate for compound 3 lay 2.5-fold (0.40 log units) above the measured number; measured number inside the range.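

In this assay, 2,4-dichlorophenyl in place of 4-bromophenyl on a double-bonded chain carbon bound to a double-bonded chain carbon gives a 2.0-fold lower number from compound 2 to compound 3 (0.30 log units; within the scatter), so this place tolerates this exchange of one halogen-bearing phenyl group for another, which a single halogen-bearing compound could not show. Against 4-cyanophenyl, the same group gives an at least 1000-fold lower number from compound 1 to compound 3 (3.00 log units; beyond the scatter), so the large gap first seen with 4-bromophenyl recurs with a second halogen-bearing group, and among these three compounds only compound 1, the nitrile, stands apart. As far as these compounds go, compound 1 has no actual number, only a limit of the assay, so the true size of both large steps remains unknown: the limit of > 100000 nM in this assay, at which 1 of the 3 values shown sits.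

The compounds shown leave open whether the number at this place depends on halogen as such, or would hold with an unsubstituted phenyl, a methoxy group or an amino group on the ring. They also do not tell whether either chlorine of 2,4-dichlorophenyl alone would give the same number.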